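A few compounds are considered here, and "the series" means these few. Any claim that something is new, unique, unknown or untested is made for them only; others in the source may bear on it.

Three compounds share one core and differ only in the aromatic group on the sulfonyl sulfur. Compound 1 `CC1CCN(c2c(S(=O)(=O)c3ccccc3)cnc3cc(Cl)ccc23)CC1` gives 93% in an assay on isolated protein for displacement of a labelled ligand from metabotropic glutamate receptor 5 (Homo sapiens), with a stated time of 60 min, tested at 1 uM; a higher number here means more inhibition at the concentration tested (going by the name of the read-out), a lower number less inhibition. Compound 2 `CC1CCN(c2c(S(=O)(=O)c3ccc(F)cc3)cnc3cc(Cl)ccc23)CC1` gives 91% in this assay, the step of a number 2 percentage points lower from compound 1 to compound 2 (within the scatter) being fluoro in place of hydrogen on an aromatic carbon. Compound 3 `COc1ccc(S(=O)(=O)c2cnc3cc(Cl)ccc3c2N2CCC(C)CC2)cc1` gives 79% in this assay, the lowest of the three, and the steps of a number 14 percentage points lower from compound 1 to compound 3 (beyond the scatter) and a number 12 percentage points lower from compound 2 to compound 3 (beyond the scatter) both place methoxy on an aromatic carbon. Compound 4 `Cc1ccc(S(=O)(=O)c2cnc3cc(Cl)ccc3c2N2CCC(C)CC2)cc1Cl` carries 3-chloro-4-methylphenyl in place of 4-methoxyphenyl on a sulfonyl sulfur. Among the compounds with values here, no measured step covers chloro or methyl on this ring, but a modest rise is expected in this assay as methoxy leaves, since compound 1 without it gave 93%, and the step of a number 8 percentage points higher from compound 3 to compound 4 (within the scatter) is expected. Compound 4 is estimated to give 87%, between 72% and 96%.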

Compound 4, a percentage reported as inhibition, at one concentration (the size of the read-out at that concentration, not a potency): 89%
Compound 4: middle estimate off by 2 percentage points, on the low side; measured number inside the range.
By their numbers in this assay, from the lowest: compounds 3, 4, 2 and 1 (each within the scatter of the next, the first and the last beyond it).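

With 3-chloro-4-methylphenyl on the sulfonyl sulfur, the read-out in this assay stays level with phenyl (a number 4 percentage points lower from compound 1 to compound 4 (within the scatter)) and with 4-fluorophenyl (a number 2 percentage points lower from compound 2 to compound 4 (within the scatter)), so the number is level with a ring carrying two added groups at this position. The step from the 4-methoxyphenyl compound also stays small (a number 10 percentage points higher from compound 3 to compound 4 (within the scatter)), so the earlier drop seen with methoxy does not extend to this ring. Nothing given here explains these numbers. Still open, going by these compounds, is how this position responds to an amine or a carboxylic acid on the ring, or to a saturated ring in place of the aromatic one.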